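This account rests on a few compounds, and the source may have more. Where it says the series, first, only, none or still open, it means among the compounds named here.

Within the data shown here, in a functional assay on HepG2 cells (Homo sapiens) for inhibition, read by MTT assay, with a stated time of 48 h (a higher number here means a weaker inhibitor, a lower number a stronger inhibitor), compound 1 `COc1ccc(C(=O)C=CNc2cc(-c3ccccc3)nn2-c2ccccc2)cc1` gives 2030 nM, the lowest of the three numbers measured so far. Compound 3 `COc1ccc(-c2ccnc3c2c(-c2ccccc2)nn3-c2ccccc2)cc1` gives 6590 nM and compound 2 `Cc1ccc(-c2ccnc3c2c(-c2ccccc2)nn3-c2ccccc2)cc1` gives 10700 nM, and both lie beyond the scatter from compound 1.

Compound 4 `O=C(C=CNc1cc(-c2ccccc2)nn1-c1ccccc1)c1ccc(F)cc1` keeps the core of compound 1 and changes one group: fluoro in place of methoxy on an aromatic carbon. This is fluoro in place of methoxy on an aromatic carbon, para to a large group, so 4-methoxyphenyl becomes 4-fluorophenyl.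

Among the measured compounds shown here, only one measured step bears on this change, and only loosely: a 1.6-fold lower number from compound 2 to compound 3 (0.21 log units; within the scatter), with methoxy in place of methyl on an aromatic carbon. That step sits on a core other than that of compound 1, and it does not involve fluoro. For the measured compounds named here, no measured compound carries fluoro, so the series offers no direct precedent.

No step beyond the scatter is therefore expected in this assay, with a slight lean towards a higher number on losing methoxy, given the small size of a 1.6-fold lower number from compound 2 to compound 3 (0.21 log units; within the scatter). The estimated step is a 1.3-fold higher number from compound 1 to compound 4 (0.11 log units; within the scatter). For compound 4 the expected value is 2600 nM, with an estimated range of 1000 nM to 6500 nM.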

Compound 4, half-maximal inhibitory concentration: 59900 nM
Beside the measured number, compound 4's estimate is 23-fold (1.36 log units) below it; the whole stated range lies below it.
By their numbers in this assay, from the lowest: compound 1; then compounds 3 and 2 (each within the scatter of the next); then compound 4.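

In this assay, the exchange of 4-methoxyphenyl for 4-fluorophenyl gives a 30-fold higher number from compound 1 to compound 4 (1.47 log units; beyond the scatter), so the place on the aromatic ring, para to a large group, is far from indifferent to the group it carries. Among these compounds, the only earlier step, a 1.6-fold lower number from compound 2 to compound 3 (0.21 log units; within the scatter), lay within the scatter and on a different core, and it gave no sign that a single exchange on an aromatic carbon could move the number this far. Nothing at hand gives a reason for a step of this size.

As far as these compounds go, what stays open is whether the large step follows from losing methoxy or from bringing in fluoro, since one exchange cannot separate the two; hydroxy, ethoxy, methyl, chloro or dimethylamino at the same place on the shared core of compound 1 would begin to tell these readings apart. Also open, from the compounds shown here alone, is whether the same exchange of methoxy for fluoro on the core of compound 3 would give a step of similar size, or whether the large step belongs to the core of compound 1 alone.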